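A Piperidine Pushed One Carbon Further from the Oxygen

The compounds below may be only part of what the source reports. "The series", "measured", "known", "first", "only" and "open" are said of these compounds alone.

Three compounds share one core and differ only in the chain hung on an oxygen on an aromatic ring. Compound 1 `NC(=O)c1ccc2[nH]c(-c3ccc(OCCCO)cc3)nc2c1` carries a short chain ending in a hydroxyl; compound 2 `NC(=O)c1ccc2[nH]c(-c3ccc(OC4CCNCC4)cc3)nc2c1` carries a ring attached straight to that oxygen; compound 3 `NC(=O)c1ccc2[nH]c(-c3ccc(OCC4CCNCC4)cc3)nc2c1` carries the same ring set one carbon further out. In a physicochemical assay for solubility, with a stated time of 3 days, at pH 7 (a higher number here means a more soluble compound, a lower number a less soluble compound), compound 1 gives 7000 nM. In this assay compound 2 gives "not determined" (no result reported), so it stands nowhere on the numbers: there is no value to place it above or below compound 1, and nothing to measure the step to compound 3 against.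

The change from compound 2 to compound 3 is (piperidin-4-yl)methyl in place of piperidin-4-yl on an oxygen on an aromatic ring. With compound 2 unmeasured, the size and direction of this step in this assay cannot be stated, and no claim beyond the scatter can be made.

Within the data shown here, the only number available is that of compound 1, 7000 nM, and the estimate for compound 3 rests on it alone. Compound 3 is expected to give about 20000 nM in this assay, within a range from 4000 nM to 150000 nM.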

Compound 3, solubility: > 400000 nM
Compound 3: no number, only a limit (the forecaster's own chance of this, stated with the estimate: 15%); middle value at least 20-fold (1.30 log units) away from the limit.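

In this assay compound 3 gives > 400000 nM, and this is a limit of the assay, not a number. Among these compounds, putting piperidin-4-yl in place of 2-hydroxyethyl on a saturated chain carbon bound to an oxygen on an aromatic ring gives an at least 57-fold higher number from compound 1 to compound 3 (1.75 log units; beyond the scatter), which is the first evidence that the group carried on this oxygen can shift the read-out well beyond the scatter. This step marks only the smallest change the data allow, and its full size stays unknown: the limit of > 400000 nM in this assay, at which 1 of the 3 values shown sits.

On these data alone, the step from compound 2 to compound 3 cannot be read, so what (piperidin-4-yl)methyl does in place of piperidin-4-yl remains open, and the large step cannot be divided between the ring and the carbon that links it to the oxygen. An open-chain amine such as 3-aminopropyl on the same oxygen, or a piperidine carrying a methyl group on its nitrogen, would help show whether the higher reading goes with the ring itself or with its nitrogen.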